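This account rests on a few compounds, and the source may have more. Where it says the series, first, only, none or still open, it means among the compounds named here.

Compound 1 `CS(=O)(=O)c1ccccc1NCc1c[nH]cn1`: < 100000 nM
Compound 2 `c1ccc(N2CCCCC2)c(NCC2=NCCN2)c1`: < 5020 nM

In a functional assay for activation of Alpha-1B adrenergic receptor (Homo sapiens) (a lower number here means that less compound is needed, a higher number that more compound is needed for the effect), compound 1 gives only a limit, < 100000 nM. In this assay compound 2 likewise gives only a limit, < 5020 nM, which is where compound 2 stands, as the limit of < 5020 nM in this assay, at which 1 of the 2 values shown sits, records. Compound 3 `c1ccc(N2CCCCC2)c(NCc2c[nH]cn2)c1` has not been measured. It differs from compound 2 by a group of 5 heavy atoms (3 carbon, 2 nitrogen; one five-membered aromatic ring with 2 hetero atoms) in place of a group of 5 heavy atoms (3 carbon, 2 nitrogen; one five-membered non-aromatic ring with 2 hetero atoms), on a saturated chain carbon bound to a nitrogen on an aromatic ring. For the measured compounds named here, no measured pair shows this change. Compound 1 carries the same imidazolyl group and sits at the limit of < 100000 nM in this assay, at which 1 of the 2 values shown sits. A step toward weaker activation, beyond the scatter, is expected, so that compound 3 is estimated at 20000 nM (range 3000 nM to 100000 nM), a step of an at least 3.9-fold higher number from compound 2 to compound 3 (0.60 log units; beyond the scatter).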

Compound 3, half-maximal effective concentration: < 5020 nM
Compound 3: only a limit was reported; the forecaster's own chance of this, stated with the estimate: 40%; middle value at least 3.9-fold (0.60 log units) away from the limit.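

In this assay, for the compounds shown here, compound 3 gives only a limit, < 5020 nM, so no step from compound 1 or compound 2 to compound 3 can be read. The compounds shown leave open how 1H-imidazol-4-yl compares with the non-aromatic ring it replaces.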